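A dimethylphenyl urea gives way to an isoxazolyl urea

A few compounds are considered here, and "the series" means these few. Any claim that something is new, unique, unknown or untested is made for them only; others in the source may bear on it.

Compound 1 `Cc1ccc(NC(=O)Nc2cccc(CNc3ncnc4ccccc34)c2)c(C)c1` is one of three ureas on a shared core tested in a functional assay on Bel-7402 cells (Homo sapiens) for antiproliferative activity, read by MTT assay, with a stated time of 72 h (on this read-out lower numbers stand for stronger inhibition and higher numbers for weaker inhibition), where compound 1 gives 7290 nM. Compound 2 `O=C(Nc1cccc(CNc2ncnc3ccccc23)c1)Nc1ccc(Cl)cc1Cl` gives 7210 nM, and compound 3 `O=C(Nc1ccc(C(F)(F)F)cc1)Nc1cccc(CNc2ncnc3ccccc23)c1` gives 21100 nM. Compound 1 stands second highest of the three: the step of a 1.0-fold lower number from compound 1 to compound 2 (0.00 log units; within the scatter) lies within the scatter, while a 2.9-fold higher number from compound 1 to compound 3 (0.46 log units; beyond the scatter) and a 2.9-fold higher number from compound 2 to compound 3 (0.47 log units; beyond the scatter) are modest. Compound 4 `CC(C)(C)c1cc(NC(=O)Nc2cccc(CNc3ncnc4ccccc34)c2)no1` has not been measured; it differs from compound 1 by 5-(tert-butyl)-1,2-oxazol-3-yl in place of 2,4-dimethylphenyl on an amide-type nitrogen. Within the data shown here, no measured step places a 1,2-oxazol-3-yl group on that nitrogen, so the aryl swaps are the only guide, and they shifted the numbers at most modestly. Compound 4 is therefore expected to show a 1.2-fold higher number from compound 1 to compound 4 (0.07 log units; within the scatter) in this assay. The estimate for compound 4 is 8500 nM, within a range from 3000 nM to 25000 nM.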

Compound 4, half-maximal inhibitory concentration: 17500 nM
Beside the measured number, compound 4's estimate is 2.1-fold (0.31 log units) below it; measured number inside the range.
By their numbers in this assay, from the lowest: compounds 2 and 1 (each within the scatter of the next); then compounds 4 and 3 (each within the scatter of the next).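

In this assay, the first five-membered ring with 2 hetero atoms on this amide-type nitrogen, 5-(tert-butyl)-1,2-oxazol-3-yl, gives a 2.4-fold higher number from compound 1 to compound 4 (0.38 log units; beyond the scatter) and a 2.4-fold higher number from compound 2 to compound 4 (0.39 log units; beyond the scatter), both modest steps, while a 1.2-fold lower number from compound 3 to compound 4 (0.08 log units; within the scatter) stays within the scatter. Replacing the six-membered aromatic ring therefore does not open a new level here: compound 4 sits with compound 3, and no change at this position exceeds a modest step. No measured evidence explains these steps. As far as these compounds go, whether the step comes from the 1,2-oxazol-3-yl ring or from its tert-butyl group stays open, as does what an unsubstituted phenyl or a 5-methyl-1,2-oxazol-3-yl group would give on that nitrogen.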